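A Bromo Swap Against a Limit of the Assay

The source may hold more compounds than are shown below. What is called first, only, known or untested is meant among the compounds shown, and "the series" means these compounds.

Of the compounds shown here, three have been tested in an ADME assay on T29 cells (Homo sapiens) for cytotoxicity, read by sulforhodamine B assay, with a stated time of 3 days (a lower number here means a stronger inhibitor, a higher number a weaker inhibitor), and none of them has yet given a number. Compound 1 (`O=Cc1cn(Cc2cccc(Cl)c2)c2ccc(F)cc12`) reads > 31600 nM as a limit of the assay and not a number. Compound 2 (`OCc1cn(Cc2cccc(F)c2)c2ccccc12`) reads > 31600 nM which is likewise a limit. Compound 3 (`OCc1cn(Cc2ccc(Cl)cc2)c2ccccc12`) reads > 31600 nM and this too is only a limit. Compound 3 thus stands with the other two at the limit of > 31600 nM in this assay, at which 3 of the 3 values shown sit, and it cannot be ranked against them.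

Compound 4 (`OCc1cn(Cc2ccc(Br)cc2)c2ccccc12`) has not yet been measured. It carries bromo in place of chloro on an aromatic carbon, para to a large group (bromo in place of chloro on an aromatic carbon). For the measured compounds named here, no pair of tested compounds differs in one place alone, so no measured step is available as a guide. In this assay the expected shift is none beyond the scatter, in either direction. Going by the values given here, that expectation rests on compound 3 and its limit of > 31600 nM as the only close reading. The expected step is a step that the limit leaves unreadable from compound 3 to compound 4 and it is estimated to stay small. For compound 4 the estimated value is 40000 nM with an expected range from 15000 nM to 100000 nM and a further limit is the likelier report.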

Compound 4, half-maximal inhibitory concentration: > 31600 nM
Compound 4: only a limit was reported (the forecaster's own chance of this, stated with the estimate: 80%); the middle value lies beyond the limit too.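

Compound 3 and compound 4 each read only as a limit of the assay, so no step between them can be read: the limit of > 31600 nM in this assay, at which 4 of the 4 values shown sit.

The compounds shown leave open how bromo and chloro compare in this assay, and whether any compound on this shared core would give a number there rather than a limit.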